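Substituent changes on the shared core: notes toward compound 4

The compounds below may be only part of what the source reports. "The series", "measured", "known", "first", "only" and "open" are said of these compounds alone.

compound 1, `COc1ccc(CS(=O)(=O)/C=C/c2ccc(F)cc2)cc1`: 1250 nM
compound 2, `COc1ccc(CS(=O)(=O)/C=C/c2ccc(Cl)cc2)cc1`: 2500 nM
compound 3, `COc1ccc(CS(=O)(=O)/C=C/c2ccc([N+](=O)[O-])cc2)cc1`: 7500 nM

In a functional assay on DU-145 cells (Homo sapiens) for antiproliferative activity, read by trypan blue exclusion (on this read-out lower numbers stand for stronger inhibition and higher numbers for weaker inhibition), compound 1 gives the lowest of the three numbers shown. Compound 2 stands nearest to it, and a 2.0-fold higher number from compound 1 to compound 2 (0.30 log units; within the scatter). Compound 3 stands furthest, with a 6.0-fold higher number from compound 1 to compound 3 (0.78 log units; beyond the scatter), and the gap between the two halogen compounds and the nitro compound also shows in a 3.0-fold higher number from compound 2 to compound 3 (0.48 log units; beyond the scatter).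

Compound 4, `COc1ccc(CS(=O)(=O)/C=C/c2ccc(F)cc2Cl)cc1`, differs from compound 1 in a single place: chloro in place of hydrogen on an aromatic carbon. The fluoro group of compound 1 remains; the chloro enters ortho to a large group and meta to that fluoro group.

Going by the values given here, none of the measured steps is this exact change. Among the compounds with values here, all three swap the one group already present on that ring for another, whereas here a second group is added. The nearest bearing comes from compound 1 to compound 2, where chloro for fluoro left the number within the scatter; the nitro steps show that a different group on the same ring can push the number well upward. For compound 4 the expected outcome is therefore a small rise, likely within the scatter: a 1.4-fold higher number from compound 1 to compound 4 (0.16 log units; within the scatter). The estimate for compound 4 is 1800 nM, with a range of 700 nM to 5000 nM.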

Compound 4, half-maximal inhibitory concentration: 2000 nM
For compound 4 the middle estimate is 1.1-fold (0.05 log units) below the measured one; measured number inside the range.
By their numbers in this assay, from the lowest: compounds 1, 4 and 2 (each within the scatter of the next); then compound 3.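

In this assay, chloro in place of hydrogen, ortho to a large group and meta to a fluoro group, gives a 1.6-fold higher number from compound 1 to compound 4 (0.20 log units; within the scatter), so at this position the added group leaves the number within the scatter. Going by these compounds alone, the earlier steps only exchanged the one group already on that ring, whereas compound 4 shows a second group added to that ring with the fluoro group kept, and this single example sets no rule for other additions. No measurement shown here bears on the reason for this outcome.

The compounds shown leave open whether an amine, a carboxylic acid or a methyl group on this same aromatic carbon would also stay within the scatter of compound 1, or would instead produce a step as large as the one seen with the nitro group of compound 3. Also open, from the compounds shown here alone, is whether chloro at this carbon would give a similarly small step if the fluoro group were replaced by that nitro group.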